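Cytotoxicity Outlook After Exchanging the Ring on the Carbonyl

The source may report more compounds than this note shows. Statements on the series, on what has been measured and on what is new or still open speak of the compounds shown alone.

Two compounds have been measured in a functional assay on C8166 cells (Homo sapiens) for cytotoxicity, read by MTT assay; a higher number here means that more compound is tolerated, a lower number that less compound is tolerated:
Compound 1 `Cc1cc(S(N)(=O)=O)ccc1NC(=O)COc1ccc(Cl)cc1NC(=O)c1ccccc1[N+](=O)[O-]`: 54800 nM
Compound 2 `Cc1cc(S(N)(=O)=O)ccc1NC(=O)COc1ccc(Cl)cc1NC(=O)c1cccc(C(F)(F)F)c1`: 124000 nM

Going by the values given here, compound 2 stands highest of these two numbers; its only neighbour is compound 1, and the step of a 2.3-fold higher number from compound 1 to compound 2 (0.35 log units; beyond the scatter) is modest but lies beyond the usual scatter. The next compound, compound 3 `Cc1cc(S(N)(=O)=O)ccc1NC(=O)COc1ccc(Cl)cc1NC(=O)c1cc(Cl)cc(Br)c1`, differs from compound 2 in one place: 3-bromo-5-chlorophenyl in place of 3-(trifluoromethyl)phenyl on a carbonyl carbon. Among the compounds with values here, no measured step covers this particular exchange; the single step known, a 2.3-fold higher number from compound 1 to compound 2 (0.35 log units; beyond the scatter), concerns a different ring on the same carbonyl carbon and therefore offers only a weak guide. On that basis the expected step, a 1.2-fold lower number from compound 2 to compound 3 (0.09 log units; within the scatter), is small, with no direction that can be called beyond the scatter. Compound 3 is estimated at 100000 nM in this assay, within a range from 40000 nM to 250000 nM.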

Compound 3, half-maximal cytotoxic concentration: 114000 nM
The estimate for compound 3 lay 1.1-fold (0.06 log units) below the measured number; low and high end bracket the measured number.
By their numbers in this assay, from the lowest: compound 1; then compounds 3 and 2 (each within the scatter of the next).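

In this assay, putting 3-bromo-5-chlorophenyl in place of 3-(trifluoromethyl)phenyl on the carbonyl carbon gives a 1.1-fold lower number from compound 2 to compound 3 (0.04 log units; within the scatter), so this assay does not separate these two rings, although their groups differ. The step of a 2.1-fold higher number from compound 1 to compound 3 (0.32 log units; beyond the scatter) shows that the separation from the 2-nitrophenyl ring of compound 1 is not tied to trifluoromethyl, since a ring carrying chlorine and bromine instead also gives it. No supporting evidence is available to explain these results.

The compounds shown leave open whether the nitro group itself or its place on the ring sets compound 1 apart, a question that 3-nitrophenyl could address. They also leave open how a ring carrying an amine or a carboxylic acid, or a saturated cyclohexyl ring, would behave at this carbonyl carbon.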